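Swapping pyridin-4-yl for 4-(trifluoromethyl)phenyl

A few compounds are considered here, and "the series" means these few. Any claim that something is new, unique, unknown or untested is made for them only; others in the source may bear on it.

In a functional assay on HCT-116 cells (Homo sapiens) for inhibition, read by MTT assay, with a stated time of 72 h (a lower number here means a stronger inhibitor, a higher number a weaker inhibitor), compound 1 `COc1cc(/C=C2\C(=O)N(Cc3ccccc3)CCc3ncn(COCc4ccccc4)c32)cc(OC)c1OC` gives 8900 nM and compound 2 `O=C1/C(=C\c2ccncc2)c2c(ncn2COCc2ccccc2)CCN1Cc1ccccc1` gives 67100 nM as the higher of the two numbers. Going by the values given here, the change to compound 3 `O=C1/C(=C\c2ccc(C(F)(F)F)cc2)c2c(ncn2COCc2ccccc2)CCN1Cc1ccccc1` is 4-(trifluoromethyl)phenyl in place of pyridin-4-yl on a double-bonded chain carbon bound to a double-bonded ring carbon and it falls at the site of the only measured step. That step, a 7.5-fold higher number from compound 1 to compound 2 (0.88 log units; beyond the scatter) on going from 3,4,5-trimethoxyphenyl to pyridin-4-yl, was modest. Compound 3 again holds a ring of carbon only there, so a partial return towards compound 1 at 8900 nM is expected, though a single step is thin evidence. The expected move is a 3.4-fold lower number from compound 2 to compound 3 (0.53 log units; beyond the scatter) towards a lower number. For compound 3 the estimated value is 20000 nM with an expected range from 7000 nM to 55000 nM overall.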

Compound 3, half-maximal inhibitory concentration: 36000 nM
Beside the measured number, compound 3's estimate is 1.8-fold (0.26 log units) below it, within the range that was stated.
By their numbers in this assay, from the lowest: compound 1; then compounds 3 and 2 (each within the scatter of the next).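

In this assay, putting a ring of carbon only at this position does not by itself restore the number of compound 1. The change gives a 1.9-fold lower number from compound 2 to compound 3 (0.27 log units; within the scatter) and so separates neither group from the other, whereas the comparison with the trimethoxy compound gives a 4.0-fold higher number from compound 1 to compound 3 (0.61 log units; beyond the scatter) and leaves 3,4,5-trimethoxyphenyl alone apart from both other groups. Nothing measured here accounts for this. As far as these compounds go, it remains open whether a phenyl carrying a single methoxy group, or an amine such as dimethylamino, would stand with compound 1 or with the other two.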